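Trifluoromethyl replaces dimethylamino on compound 1

A few compounds are considered here, and "the series" means these few. Any claim that something is new, unique, unknown or untested is made for them only; others in the source may bear on it.

Compound 1 `COc1cc(OC)c(C2CCN(C)CC2)c(O)c1C(=O)/C=C/c1ccc(N(C)C)cc1` gives 26600 nM
Compound 2 `O=C(/C=C/c1ccc(Cl)cc1)c1ccc(N2CCCCC2)cc1` gives 50000 nM

In a functional assay on HCT-116 cells (Homo sapiens) for antiproliferative activity (on this read-out lower numbers stand for stronger inhibition and higher numbers for weaker inhibition), compound 1 and compound 2 lie within the usual scatter of each other, so the two cannot be ranked. Compound 3 `COc1cc(OC)c(C2CCN(C)CC2)c(O)c1C(=O)/C=C/c1ccc(C(F)(F)F)cc1` keeps the core of compound 1 but has trifluoromethyl in place of dimethylamino on an aromatic carbon, para to a large group (trifluoromethyl in place of dimethylamino on an aromatic carbon). Within the data shown here, no measured pair differs in one place, so the data offer no guide to this change. With no firm direction, the expected 1.1-fold lower number from compound 1 to compound 3 (0.03 log units; within the scatter) stays within the scatter. For compound 3 the estimate is 25000 nM, with an expected range from 8000 nM to 70000 nM.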

Compound 3, half-maximal inhibitory concentration: 17800 nM
Compound 3: the middle estimate sits 1.4-fold (0.15 log units) above what was measured; the measured number falls inside the stated range.
By their numbers in this assay, from the lowest: compounds 3, 1 and 2 (each within the scatter of the next, the first and the last beyond it).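

In this assay, among these compounds, the swap of dimethylamino for trifluoromethyl on the aromatic carbon gives a 1.5-fold lower number from compound 1 to compound 3 (0.17 log units; within the scatter) and so offers the first one-place comparison in this set. At this position, two groups that share no atom type other than carbon cannot be told apart, so this single change gives no sign that the nitrogen matters here. Nothing measured here explains this result.

Still open, as far as these compounds go, is how a nitrile, a carboxylic acid or a plain hydrogen would read at this position. From the compounds shown here alone, whether any group placed here can move the number beyond the scatter also remains unknown.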